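The source may hold more compounds than are shown below. What is called first, only, known or untested is meant among the compounds shown, and "the series" means these compounds.

Working notes on the series. Of the compounds shown here, two have been measured in a functional assay on MCF7R cells (Homo sapiens) for cytotoxicity, tested at 10 uM; a lower number here means less inhibition, a higher number more inhibition at the concentration tested (going by the name of the read-out). Compound 1 `N#Cc1c(-c2ccc(Cl)cc2)sc2ccccc12` carries a chloro on its pendant ring and in this assay compound 1 gives 18%. Compound 2 `N#Cc1c(-c2cccc(Cl)c2)sc2ccccc12` carries its chloro at another site of the same ring and in this assay compound 2 gives 20%. Compound 2 stands at the upper of the two numbers shown, but the gap to compound 1 lies within the scatter, so the two values read as the same.

The next compound, compound 3 `N#Cc1c(-c2ccccc2)sc2ccccc12`, is not yet measured. Relative to compound 2 the change is hydrogen in place of chloro on an aromatic carbon. With compound 1 and compound 2 sitting together, the chloro itself appears to carry little weight, and the step from compound 2 to compound 3 is expected to be small, at most a slight fall, a number 5 percentage points lower from compound 2 to compound 3 (within the scatter). For compound 3 in this assay the estimate is 15%, between 2% and 30%.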

Compound 3, a percentage reported as inhibition, at one concentration (the size of the read-out at that concentration, not a potency): 37%
Beside the measured number, compound 3's estimate is 22 percentage points below it; measured number outside the range, above it.
By their numbers in this assay, from the lowest: compounds 1 and 2 (each within the scatter of the next); then compound 3.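

In this assay the chloro does matter, which the earlier pair could not show: hydrogen in place of chloro on an aromatic carbon gives a number 17 percentage points higher from compound 2 to compound 3 (beyond the scatter), and the same change at the other site of the ring gives a number 19 percentage points higher from compound 1 to compound 3 (beyond the scatter). Both steps point the same way, so the pendant ring without a chloro stands apart from the two chloro compounds, while the site of the chloro makes no readable difference between compound 1 and compound 2. No measurement at hand accounts for this rise.

From the compounds shown here alone, whether the lower number goes with chlorine alone or with any group on this ring remains open, as a fluoro, a methoxy or an amine at the same place would tell. Also open, going by these compounds, is how much of the number rests on the nitrile, which all three compounds share, and a carboxylic acid in its place would test that.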